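A few compounds are considered here, and "the series" means these few. Any claim that something is new, unique, unknown or untested is made for them only; others in the source may bear on it.

Measured compounds in a toxicity assay on GES1 cells (Homo sapiens) for inhibition, read by MTT assay, with a stated time of 72 h; on this read-out higher numbers stand for weaker inhibition and lower numbers for stronger inhibition:
compound 1, `Cc1cc(N2CC[C@@H](C)[C@@H](N(C)c3ncnc4[nH]ccc34)C2)n2nc(SCc3ccc(C(F)(F)F)cc3)nc2n1`: 17300 nM
compound 2, `Cc1cc(N2CC[C@@H](C)[C@@H](N(C)c3ncnc4[nH]ccc34)C2)n2nc(SCc3ccc([N+](=O)[O-])cc3)nc2n1`: 36600 nM
compound 3, `COc1ccc(CSc2nc3nc(C)cc(N4CC[C@@H](C)[C@@H](N(C)c5ncnc6[nH]ccc56)C4)n3n2)cc1`: > 100000 nM

The three compounds differ only in one group on the benzyl portion. For compound 3 the value in this assay is a limit, not a number; compound 3 sits at the limit of > 100000 nM in this assay, at which 1 of the 3 values shown sits, and so stands at the top of the range shown, with the weakest inhibition of the three, since both steps into it are beyond the scatter. Compound 4 `Cc1ccc(CSc2nc3nc(C)cc(N4CC[C@@H](C)[C@@H](N(C)c5ncnc6[nH]ccc56)C4)n3n2)cc1` is still to be measured; it differs from compound 3 in one place: methyl in place of methoxy on an aromatic carbon. Among the measured compounds shown here, no measured step swaps methoxy for methyl, so the steps that bear on it are those into compound 3: an at least 5.7-fold higher number from compound 1 to compound 3 (0.76 log units; beyond the scatter) and an at least 2.7-fold higher number from compound 2 to compound 3 (0.43 log units; beyond the scatter). Both leave the methoxy compound with the higher number, and a 2.1-fold higher number from compound 1 to compound 2 (0.33 log units; beyond the scatter) shows that the group at this place moves the number only modestly among the three. Taking methoxy away may bring the number down somewhat, but with compound 3 known only as a limit the size of that step cannot be fixed. Compound 4 is expected to land near the limit again, the estimated step being an at least 1.2-fold lower number from compound 3 to compound 4 (0.09 log units; that floor lies within the scatter) in this assay. The estimate for compound 4 is 80000 nM, within 30000 nM to 250000 nM.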

Compound 4, half-maximal inhibitory concentration: 82500 nM
Beside the measured number, compound 4's estimate is 1.0-fold (0.01 log units) below it; the measured number falls inside the stated range.
By their numbers in this assay, from the lowest: compound 1; then compound 2; then compound 4. At a limit, above all of these: compound 3.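

In this assay, methyl in place of methoxy gives an at least 1.2-fold lower number from compound 3 to compound 4 (0.08 log units; that floor lies within the scatter), which is only a floor, so the true size of this change remains unfixed, and the value for compound 3 remains a limit: the limit of > 100000 nM in this assay, at which 1 of the 4 values shown sits. Compound 4 adds an exact number for a group that is neither trifluoromethyl nor nitro at this aromatic carbon, para to a large group, and the steps into it read a 2.3-fold higher number from compound 2 to compound 4 (0.35 log units; beyond the scatter) and a 4.8-fold higher number from compound 1 to compound 4 (0.68 log units; beyond the scatter). Among the four compounds, the methyl and methoxy compounds thus both carry higher numbers than the trifluoromethyl and nitro compounds, with no compound going against this split, though compound 3 and compound 4 cannot be placed in order on the present data.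

Open, going by these compounds, is whether an amine or a carboxylic acid at this place would stay within the span set by these four compounds or move the number outside it. Also open, on these data alone, is whether a longer chain in place of methyl would keep the number near that of compound 4, and how far compound 3 truly lies from compound 4.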